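The source may hold more compounds than are shown below. What is called first, only, known or untested is meant among the compounds shown, and "the series" means these compounds.

Measured compounds:
Compound 1 `Cc1cc(C)cc(C(=O)Nc2nc3ccc(NC(=O)CSc4ccc(Cl)cc4)cc3s2)c1` gives 65100 nM in a functional assay on HCT-116 cells (Homo sapiens) for antiproliferative activity, read by MTT assay, with a stated time of 72 h; a lower number here means a stronger inhibitor, a higher number a weaker inhibitor.
Compound 2 `O=C(Cc1nnc(NC(=O)c2ccc(Cl)cc2)s1)N/N=C/c1ccc(O)cc1` gives 68300 nM in this assay.
Compound 3 `Cc1cc(C)cc(C(=O)Nc2nc3ccc(NC(=O)CSc4cccc(O)c4)cc3s2)c1` gives 5130 nM in this assay.

Among these three numbers compound 1 stands second highest. Its nearest neighbour is compound 2, whose value lies within the scatter of it, so no order between the two can be claimed. Among the compounds with values here, the only step measured from compound 1 leads to compound 3: a 13-fold lower number from compound 1 to compound 3 (1.10 log units; beyond the scatter). That step sits on the sulfur-bearing side of the shared core.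

Compound 4 `O=C(CSc1ccc(Cl)cc1)Nc1ccc2nc(NC(=O)c3ccc(C(F)(F)F)cc3)sc2c1` has not yet been measured. It differs from compound 1 at the opposite end of the molecule: 4-(trifluoromethyl)phenyl in place of 3,5-dimethylphenyl on a carbonyl carbon. The exchange sits on a carbonyl carbon whose other neighbour is an amide-type nitrogen, and it leaves the sulfur-linked 4-chlorophenyl of compound 1 in place. Within the data shown here, no measured pair shows what an exchange of the amide-side aryl group does in this assay; the single measured step concerns a different position and therefore cannot be carried over. With no evidence for a change in either direction, compound 4 is expected to stay close to compound 1, a step of a 1.1-fold lower number from compound 1 to compound 4 (0.04 log units; within the scatter) that need not exceed the scatter. Compound 4 is therefore estimated at 60000 nM, with a range from 20000 nM to 150000 nM.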

Compound 4, half-maximal inhibitory concentration: 930 nM
Compound 4: middle estimate off by 65-fold (1.81 log units), on the high side; measured number below the stated range.
By their numbers in this assay, from the lowest: compound 4; then compound 3; then compounds 1 and 2 (each within the scatter of the next).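

In this assay, within the data shown here, replacing 3,5-dimethylphenyl with 4-(trifluoromethyl)phenyl on a carbonyl carbon whose other neighbour is an amide-type nitrogen gives a 70-fold lower number from compound 1 to compound 4 (1.85 log units; beyond the scatter), showing that this end of the molecule can also move the number by a margin beyond the scatter, which the single earlier step on the sulfur-bearing side could not show. The sulfur-linked 4-chlorophenyl stays in place, and both exchanged groups are one six-membered aromatic ring of carbon only, with no hydrogen-bond donors or acceptors and no net charge, so those counts do not separate them, while the entering group has more heavy atoms and brings in fluorine. Nothing available here accounts for the size of this step.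

The compounds shown leave open whether the trifluoromethyl group or the loss of the two methyl groups carries the step, a question that a plain phenyl or a 4-methylphenyl on the same carbonyl carbon could address. It also remains open whether this step combines with the one on the sulfur-bearing side, a 13-fold lower number from compound 1 to compound 3 (1.10 log units; beyond the scatter), as 3-hydroxyphenyl and 4-(trifluoromethyl)phenyl stand together in no compound shown.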